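Ethyl to cyclopropyl at the top of the binding scale

This account rests on a few compounds, and the source may have more. Where it says the series, first, only, none or still open, it means among the compounds named here.

In an ADME assay on a cell-free system (plasma, Homo sapiens) for protein binding, compound 1 `CNc1nccc(N2CC[C@H](NC(=O)Nc3ccc(OC)cc3)C2)n1` gives 80% and compound 2 `CNc1nccc(N2CC[C@H](NC(=O)Nc3ccc(Cl)c(C(F)(F)F)c3)C2)n1` gives 99.8% on the same scale. Compound 3 `CCNc1nccc(N2CC[C@H](NC(=O)Nc3ccc(Cl)c(C(F)(F)F)c3)C2)n1` gives > 99.9% as a limit of the assay, not a number. Compound 4 `O=C(Nc1ccc(Cl)c(C(F)(F)F)c1)N[C@H]1CCN(c2ccnc(NC3CC3)n2)C1` carries cyclopropyl in place of the ethyl of compound 3 on a nitrogen on an aromatic ring (cyclopropyl in place of ethyl on a nitrogen on an aromatic ring). Among the compounds with values here, with (an at least 2.0-fold lower unbound fraction from compound 2 to compound 3 (0.30 log units; that floor lies within the scatter)) as the one measured step on this chain, a methyl in place of hydrogen, no change beyond the scatter is expected here. The expected step is (an at least 1.5-fold higher unbound fraction from compound 3 to compound 4 (0.17 log units; that floor lies within the scatter)) which keeps binding near the top of the scale. The estimated value for compound 4 is 99.85% within a range of 99.6% to 99.95% and it may also come back as a limit.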

Compound 4, plasma protein binding: > 99.9%
Compound 4 gave a limit, no number; the forecaster's own chance of this, stated with the estimate: 40%; at least 1.5-fold (0.17 log units) (unbound fraction) between middle value and limit.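

In this assay compound 4 gives > 99.9%, which is a limit of the assay and not a number. With cyclopropyl now at the same limit as ethyl on this nitrogen, the step between these two groups cannot be read: the limit of > 99.9% in this assay, at which 2 of the 4 values shown sit.

Replacing methyl with cyclopropyl gives an at least 2.0-fold lower unbound fraction from compound 2 to compound 4 (0.30 log units; that floor lies within the scatter), so the three-membered ring, like ethyl, leaves binding at the top of the scale.

From the compounds shown here alone, it remains open whether a chain ending in an amine or a carboxylic acid on this nitrogen would bring binding down to a readable number.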